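The source may hold more compounds than are shown below. What is called first, only, known or untested is meant among the compounds shown, and "the series" means these compounds.

Working notes on the series. Compound 1 `Nc1nn(C(=O)Nc2ccc(Cc3ccccc3)cc2)c2ccccc12` is the parent of the pair measured so far; in a functional assay on OVCAR-4 cells (Homo sapiens) for antiproliferative activity, read by sulforhodamine B assay, with a stated time of 48 h (a lower number here means a stronger inhibitor of growth, a higher number a weaker inhibitor of growth), compound 1 gives 10700 nM. Compound 2 `Nc1nn(C(=O)Nc2ccc(Cc3ccccc3)cc2)c2ccc(Cl)cc12` carries a chloro on an aromatic carbon of the shared core, and in this assay compound 2 gives 5730 nM. Among the compounds with values here, the single step between them, a 1.9-fold lower number from compound 1 to compound 2 (0.27 log units; within the scatter), is the only comparison available. Compound 2 therefore holds the lower of the two numbers, though it sits within the scatter of compound 1. Compound 3 `Nc1ccc2c(c1)c(N)nn2C(=O)Nc1ccc(Cc2ccccc2)cc1` is to be measured; it differs from compound 2 by amino in place of chloro on an aromatic carbon. Within the data shown here, no measured step exchanges one substituent for another at that carbon; the only step at it, a 1.9-fold lower number from compound 1 to compound 2 (0.27 log units; within the scatter), stayed within the scatter and gives no sign that this carbon moves the read-out much. For compound 3 the expected change in this assay is a 1.4-fold higher number from compound 2 to compound 3 (0.14 log units; within the scatter), none beyond the scatter. The estimate for compound 3 is 8000 nM, with a range from 3000 nM to 22000 nM.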

Compound 3, concentration for 50% growth inhibition: 8290 nM
Estimate against measurement, compound 3: 1.0-fold (0.02 log units) below; the measured number falls inside the stated range.
By their numbers in this assay, from the lowest: compounds 2, 3 and 1 (each within the scatter of the next).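

Within the data shown here, the first exchange of one substituent for another at this carbon, amino in place of chloro, gives in this assay a 1.4-fold higher number from compound 2 to compound 3 (0.16 log units; within the scatter) even though amino, unlike chloro, counts a hydrogen-bond donor and acceptor. Set against hydrogen, amino gives a 1.3-fold lower number from compound 1 to compound 3 (0.11 log units; within the scatter) and so hydrogen, chloro and amino at this carbon all stand within the scatter of one another. No measurement available bears on why these exchanges leave the read-out so little changed.

On these data alone, whether a carboxylic acid, a methoxy group or a longer chain at this carbon would move the number beyond the scatter stays open. Also open is how the read-out responds to changes elsewhere on the molecule, as every step shown falls at this one carbon.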